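Aryl Replacement of Bromo on a Fused Core

The compounds below may be only part of what the source reports. "The series", "measured", "known", "first", "only" and "open" are said of these compounds alone.

Compound 1 `Brc1cn2ccnc2c(-c2ccc3ncn(C4CCCCC4)c3c2)n1`: 1.5%
Compound 2 `O=Cc1ccc(-c2cn3ccnc3c(-c3ccc4ncn(C5CCCCC5)c4c3)n2)cc1`: 32%
Compound 3 `CC(=O)c1ccc(-c2cn3ccnc3c(-c3ccc4ncn(C5CCCCC5)c4c3)n2)cc1`: 3.02%

In a functional assay on U-251 cells (Homo sapiens) for inhibition, read by sulforhodamine B assay, with a stated time of 48 h, tested at 10 uM (on this read-out higher numbers stand for more inhibition at the one concentration tested (going by the name of the read-out) and lower numbers for less inhibition), compound 1 gives the lowest of the three numbers. Its nearest neighbour is compound 3, a step of a number 1.5 percentage points higher from compound 1 to compound 3 (within the scatter); its furthest is compound 2, a step of a number 30.5 percentage points higher from compound 1 to compound 2 (beyond the scatter). Between those two aryl analogues the step of a number 29 percentage points lower from compound 2 to compound 3 (beyond the scatter) separates them.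

Compound 4 `Fc1ccccc1-c1cn2ccnc2c(-c2ccc3ncn(C4CCCCC4)c3c2)n1` differs from compound 1 in one place: 2-fluorophenyl in place of bromo on an aromatic carbon. Both measured steps from compound 1 bear on this change, since each also puts an aryl group where bromo stood; one was large, the other within the scatter, and compound 4 carries no carbonyl. Compound 4 is therefore expected to move only slightly, a step of a number 6.5 percentage points higher from compound 1 to compound 4 (within the scatter), giving an estimated 8% with a range from -5% to 30%.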

Compound 4, a percentage reported as inhibition, at one concentration (the size of the read-out at that concentration, not a potency): 11.4%
For compound 4 the middle estimate is 3.4 percentage points below the measured one; measured number inside the range.
By their numbers in this assay, from the lowest: compounds 1, 3 and 4 (each within the scatter of the next); then compound 2.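

In this assay, for the compounds shown here, the 2-fluorophenyl group, the first aryl group here without a carbonyl, leaves compound 4 level with the bromo compound (a number 9.9 percentage points higher from compound 1 to compound 4 (within the scatter)) and with the 4-acetylphenyl analogue (a number 8.4 percentage points higher from compound 3 to compound 4 (within the scatter)). Only the 4-formylphenyl analogue stands apart (a number 20.6 percentage points lower from compound 2 to compound 4 (beyond the scatter)), so among these compounds a phenyl ring at this position does not by itself raise the number, with compound 2 the one case against that. Nothing available here accounts for this. On these data alone, whether a carboxylic acid or an amine in place of the formyl group of compound 2 would keep its number stays open.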